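Thiophene for bromophenyl in a cytotoxicity series

The source may hold more compounds than are shown below. What is called first, only, known or untested is meant among the compounds shown, and "the series" means these compounds.

The compounds share a fused core and differ only in the aryl group on a saturated ring carbon. Compound 1 `CCOC(=O)C12C(=O)OCC=C1COC2c1ccccc1` carries a phenyl group there. In a functional assay on QGY cells (Homo sapiens) for cytotoxicity, read by MTT assay (a higher number here means a weaker inhibitor, a lower number a stronger inhibitor), compound 1 gives a limit of > 1000000 nM rather than a number. Compound 2 `CCOC(=O)C12C(=O)OCC=C1COC2c1ccccc1F` bears a fluorine on that aromatic ring, and in this assay compound 2 likewise gives only the limit > 1000000 nM. Compound 3 `CCOC(=O)C12C(=O)OCC=C1COC2c1ccc(Br)cc1` carries a bromine on the ring, and compound 3 also stands at the limit > 1000000 nM in this assay. The steps a step that the two limits leave unreadable from compound 1 to compound 2, a step that the two limits leave unreadable from compound 1 to compound 3 and a step that the two limits leave unreadable from compound 2 to compound 3 therefore cannot be sized, because of the limit of > 1000000 nM in this assay, at which 3 of the 3 values shown sit.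

Compound 4 `CCOC(=O)C12C(=O)OCC=C1COC2c1cccs1` replaces the aryl group: thiophen-2-yl in place of 4-bromophenyl on a saturated ring carbon. Going by the values given here, no measured step reports a readable change for any aryl exchange on this carbon, so there is no basis for expecting a step out of the region where the three measured compounds sit. Compound 4 is therefore expected to remain at or near the limit, with an estimated value of 1000000 nM and a range from 300000 nM to 3000000 nM. The step of a number no higher from compound 3 to compound 4 (the limit leaves the size open) is expected to be no larger than the scatter.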

Compound 4, half-maximal inhibitory concentration: > 1000000 nM
Compound 4 gave a limit, no number; the forecaster's own chance of this, stated with the estimate: 85%; the middle value sits exactly at the limit.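

In this assay compound 4 gives > 1000000 nM as a limit and not a number. Its steps from compound 1, compound 2 and compound 3 therefore cannot be read: the limit of > 1000000 nM in this assay, at which 4 of the 4 values shown sit. The compounds shown leave open whether any aryl group on this saturated ring carbon gives a readable value.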